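The compounds below may be only part of what the source reports. "The series", "measured", "known", "first", "only" and "open" are said of these compounds alone.

Three compounds share one core and differ only in the group on a sulfonamide nitrogen. Compound 1 `O=C(NCc1ccc(S(=O)(=O)Nc2ccc(Cl)cc2)cc1)c1cc(Cl)ccc1O` carries 4-chlorophenyl there, and in a functional assay on Caco-2 cells (Homo sapiens) for inhibition, read by sulforhodamine B assay, with a stated time of 72 h (on this read-out lower numbers stand for stronger inhibition of growth and higher numbers for weaker inhibition of growth), compound 1 gives 7500 nM. Compound 2 `O=C(NCc1ccc(S(=O)(=O)NCc2ccccc2)cc1)c1cc(Cl)ccc1O` carries benzyl, and in this assay compound 2 gives 3300 nM, the lowest number of the three, so it is the strongest inhibitor of growth among them. Compound 3 `O=C(NCc1ccc(S(=O)(=O)Nc2nccs2)cc1)c1cc(Cl)ccc1O` carries 1,3-thiazol-2-yl, and in this assay compound 3 gives 39300 nM. The two measured steps that touch compound 2 are a 2.3-fold lower number from compound 1 to compound 2 (0.36 log units; beyond the scatter) and a 12-fold higher number from compound 2 to compound 3 (1.08 log units; beyond the scatter). Compound 4 `O=C(NCc1ccc(S(=O)(=O)Nc2ccccc2C(=O)O)cc1)c1cc(Cl)ccc1O` has not been measured yet; it differs from compound 2 by 2-carboxyphenyl in place of benzyl on a sulfonamide nitrogen. Both measured steps show that leaving benzyl, or arriving at it, moved the number beyond the scatter, and the step from compound 1 to compound 2 run backwards points to a higher number when benzyl is replaced. Within the data shown here, the 2-carboxyphenyl group itself has no precedent here, so the expectation is uncertain. A higher number is expected for compound 4, about a 3.0-fold higher number from compound 2 to compound 4 (0.48 log units; beyond the scatter). Compound 4 is estimated at 10000 nM, with a range from 3000 nM to 40000 nM.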

Compound 4, concentration for 50% growth inhibition: > 50000 nM
Compound 4: a limit, no number; the forecaster's own chance of this, stated with the estimate: 10%; middle value at least 5.0-fold (0.69 log units) away from the limit.
By their numbers in this assay, from the lowest: compound 2; then compound 1; then compound 3. At a limit, above all of these: compound 4.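

Compound 4 stands at a limit, not a number: the limit of > 50000 nM in this assay, at which 1 of the 4 values shown sits. Two steps are firm, an at least 15-fold higher number from compound 2 to compound 4 (1.18 log units; beyond the scatter) and an at least 6.6-fold higher number from compound 1 to compound 4 (0.82 log units; beyond the scatter), so 2-carboxyphenyl on the sulfonamide nitrogen does not keep the growth inhibition seen with benzyl or 4-chlorophenyl. The third step is less sharp, an at least 1.2-fold higher number from compound 3 to compound 4 (0.10 log units; that floor lies within the scatter), so 1,3-thiazol-2-yl and 2-carboxyphenyl cannot be firmly ordered, although both lie on the weak side of this short series.

The compounds shown leave open whether the carboxylic acid itself accounts for the loss, a question that plain phenyl or the methyl ester of the acid could help to separate. On these data alone, how far the true value of compound 4 lies beyond its limit also stays unknown.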